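Swapping iodine for a hydroxyphenyl ring on a shared core

The source may report more compounds than this note shows. Statements on the series, on what has been measured and on what is new or still open speak of the compounds shown alone.

Compound 3 `Cc1cc(I)cn2c(CSCCc3ccccc3)cnc12` is measured in an ADME assay on HEL cells (Homo sapiens) for cytotoxicity, with a stated time of 3 days; on this read-out higher numbers stand for lower toxicity in this test and lower numbers for higher toxicity in this test. For compound 3 that reading is only a limit of the assay, > 50 ug/mL, not a number, a case of the limit of > 50 ug/mL in this assay, at which 1 of the 3 values shown sits. Compound 4 `Cc1cc(-c2ccccc2O)cn2c(CSCCc3ccccc3)cnc12` differs from it in one place: 2-hydroxyphenyl in place of iodo on an aromatic carbon.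

Among the measured compounds shown here, no measured step exchanges an iodine for an aromatic ring, so the nearest guide is the pair of compound 1 `Cc1cc(-c2ccc(O)cc2)c2ncc(CSCCc3ccccc3)n2c1` and compound 2 `Cc1cc(-c2cccc([N+](=O)[O-])c2)c2ncc(CSCCc3ccccc3)n2c1`, which share the core and carry different rings at the same place. In this assay compound 1 gives 13.7 ug/mL. Compound 2 gives 47 ug/mL, and the step of a 3.4-fold higher number from compound 1 to compound 2 (0.54 log units; beyond the scatter) shows that the choice of ring at this position shifts the number modestly. Compound 1, carrying a hydroxyphenyl ring like compound 4, sits well inside the measurable range, so a numeric value is expected for compound 4.

Compound 4 is therefore expected to give about 20 ug/mL, between 8 ug/mL and 50 ug/mL. That estimate implies an expected step of an at least 2.5-fold lower number from compound 3 to compound 4 (0.39 log units; beyond the scatter) toward lower numbers.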

Compound 4, half-maximal cytotoxic concentration: > 50 ug/mL
Compound 4 ended at the assay's limit; the forecaster's own chance of this, stated with the estimate: 25%; middle value at least 2.5-fold (0.39 log units) away from the limit.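

Compound 3 and compound 4 both sit at a limit of the assay rather than at a number, so no step between them can be read: the limit of > 50 ug/mL in this assay, at which 2 of the 4 values shown sit.

The compounds shown leave open whether 2-hydroxyphenyl in place of iodo changes the number at all, and by how much.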